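This account rests on a few compounds, and the source may have more. Where it says the series, first, only, none or still open, it means among the compounds named here.

The measured compounds and their values in an assay on isolated protein for inhibition of Thymidylate synthase (Mus musculus); on this read-out lower numbers stand for stronger inhibition and higher numbers for weaker inhibition:

compound 1, `C=CCN(Cc1ccc2nc(C)[nH]c(=O)c2c1)c1ccc(C(=O)N[C@@H](CCC(=O)O)C(=O)O)cc1F`, 5160 nM;
compound 2, `CCN(Cc1ccc2nc(C)[nH]c(=O)c2c1)c1ccc(C(=O)N[C@@H](CCC(=O)O)C(=O)O)c(C)c1`, 320 nM;
compound 3, `CCN(Cc1ccc2nc(C)[nH]c(=O)c2c1)c1ccc(C(=O)N[C@@H](CCC(=O)O)C(=O)O)c(F)c1`, 45 nM.

Compound 3 gives the lowest number of the three. Among the compounds with values here, its nearest neighbour is compound 2, and the single step between them, a 7.1-fold lower number from compound 2 to compound 3 (0.85 log units; beyond the scatter), lies beyond the scatter. Compound 1 stands furthest away; it differs from compound 3 in more than one place, so its value is only compared, not traced to a single change.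

Compound 4, `Cc1nc2ccc(CN(CC#N)c3ccc(C(=O)N[C@@H](CCC(=O)O)C(=O)O)c(F)c3)cc2c(=O)[nH]1`, is not yet measured. It differs from compound 3 in one place: cyano in place of methyl on a saturated chain carbon bound to a nitrogen on an aromatic ring. Within the data shown here, no measured step touches this chain carbon; the one step known, from compound 2 to compound 3, concerns a group on an aromatic carbon and says nothing direct about a cyano entering in place of methyl here. Among the measured compounds shown here, with no precedent, the change is expected to shift this assay only modestly, if at all, and more likely toward a higher number. Compound 4 is estimated at 100 nM, within 25 nM to 400 nM, a step of a 2.2-fold higher number from compound 3 to compound 4 (0.35 log units; beyond the scatter).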

Compound 4, half-maximal inhibitory concentration: 170 nM
Compound 4: the middle estimate sits 1.7-fold (0.23 log units) below what was measured; the range from low to high includes it.
By their numbers in this assay, from the lowest: compound 3; then compounds 4 and 2 (each within the scatter of the next); then compound 1.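

In this assay, this chain carbon bound to a nitrogen on an aromatic ring proves to be a place where a single change registers: cyano in place of methyl, which also reads as ethyl to cyanomethyl, gives a 3.8-fold higher number from compound 3 to compound 4 (0.58 log units; beyond the scatter) and so lies beyond the scatter. Within the data shown here, the one earlier step concerned a group on an aromatic carbon, so this is the first evidence at this position, and it shows that the cyanomethyl compound 4 retains 170 nM of inhibition, with a modest step. Nothing in the data shown explains why the number rises.

The compounds shown leave open whether the rise belongs to the nitrile itself or to the extra heavy atom, which a propyl chain at this place could help separate. They also leave open how an amine or a carboxylic acid on this chain would read.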